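Benzocyclobutane-piperazine series: chain and halogen change, oral agonist dose

This account rests on a few compounds, and the source may have more. Where it says the series, first, only, none or still open, it means among the compounds named here.

Measured so far:
compound 1 `C1=C(CCN2CCN(c3cccc4c3OCCO4)CC2)c2ccccc2CCC1` — > 40 mg/kg
compound 2 `Clc1cccc2c1CC2CCCN1CCN(c2cccc3c2OCCO3)CC1` — > 10 mg/kg
compound 3 `c1ccc2c(c1)CC2CCN1CCN(c2cccc3c2OCCCO3)CC1` — 40 mg/kg

In a functional assay on the whole organism for agonist activity, with Rattus norvegicus as the target (a lower number here means that less compound is needed, a higher number that more compound is needed for the effect), compound 1 reaches only a limit, > 40 mg/kg, and this is a limit of the assay rather than a number (the limit of > 40 mg/kg in this assay, at which 1 of the 3 values shown sits). Compound 3 gives a number, 40 mg/kg. Compound 2 likewise stops at a limit, > 10 mg/kg (the limit of > 10 mg/kg in this assay, at which 1 of the 3 values shown sits), so it cannot be ranked against compound 3 or compound 1. Among the measured compounds shown here, no pair of measured compounds differs in one place, so no measured step is available.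

Compound 4 `c1ccc2c(c1)CC2CCCCN1CCN(c2cccc3c2OCCO3)CC1` differs from compound 2 by a group of 9 heavy atoms (9 carbon; one four-membered non-aromatic ring of carbon only, one six-membered aromatic ring of carbon only) in place of a group of 9 heavy atoms (8 carbon, 1 chlorine; one four-membered non-aromatic ring of carbon only, one six-membered aromatic ring of carbon only), on a saturated chain carbon, three bonds along the chain from an amine nitrogen in a ring. With compound 2 known only as a limit, the step that the limit leaves unreadable from compound 2 to compound 4 is expected to be of unknown direction and likely within the scatter. For compound 4 a minimum effective dose of 40 mg/kg is estimated, between 15 mg/kg and 100 mg/kg.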

Compound 4, minimum effective dose: > 10 mg/kg
Compound 4 gave a limit, no number; the forecaster's own chance of this, stated with the estimate: 50%; the middle value is on the limit's open side.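

Compound 2 and compound 4 both end at a limit of the assay, not a number, so no step between them can be read: the limit of > 10 mg/kg in this assay, at which 2 of the 4 values shown sit.

The compounds shown leave open whether the chlorine-bearing group and the all-carbon group in its place differ in minimum effective dose.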